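Series notes: from compound 3 to compound 4

The compounds below may be only part of what the source reports. "The series", "measured", "known", "first", "only" and "open" are said of these compounds alone.

Measured so far in a functional assay on MDA-MB-231 cells (Homo sapiens) for cytotoxicity, read by MTT assay, with a stated time of 72 h; a lower number here means a stronger inhibitor, a higher number a weaker inhibitor:
compound 1 `COc1cc2c(Oc3ccc(NC(=O)c4nn(-c5ccccc5)c(=O)c5ccccc45)cc3F)ccnc2cc1OCCCN1CCCCC1` gives 1880 nM.
compound 2 `COc1cc2c(Oc3ccc(NC(=O)c4nn(-c5ccccc5F)c(=O)c5ccccc45)cc3F)ccnc2cc1OCCCN1CCCCC1` gives 910 nM.
compound 3 `COc1cc2c(Oc3ccc(NC(=O)c4nn(-c5ccc(Br)cc5)c(=O)c5ccccc45)cc3F)ccnc2cc1OCCCN1CCCCC1` gives 1130 nM.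

Compound 3 stands second highest of the three numbers. Its nearest neighbour is compound 2, with a 1.2-fold higher number from compound 2 to compound 3 (0.09 log units; within the scatter) within the scatter; its furthest is compound 1, with a 1.7-fold lower number from compound 1 to compound 3 (0.22 log units; within the scatter), also within the scatter.

Compound 4 `COc1ccc(-n2nc(C(=O)Nc3ccc(Oc4ccnc5cc(OCCCN6CCCCC6)c(OC)cc45)c(F)c3)c3ccccc3c2=O)cc1` differs from compound 3 by methoxy in place of bromo on an aromatic carbon. Among the measured compounds shown here, no measured step exchanges one substituent for another on that carbon with a number beyond the scatter: a 1.7-fold lower number from compound 1 to compound 3 (0.22 log units; within the scatter) shows that bromo in place of hydrogen there changes little, and a 1.2-fold higher number from compound 2 to compound 3 (0.09 log units; within the scatter) shows the 4-bromophenyl and 2-fluorophenyl compounds sitting together. For the measured compounds named here, the only step beyond the scatter, a 2.1-fold lower number from compound 1 to compound 2 (0.32 log units; beyond the scatter), concerns fluoro in place of hydrogen and does not bear on methoxy in place of bromo. So no step beyond the scatter is expected in this assay on going to compound 4, in either direction.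

Compound 4 is therefore expected at 1200 nM in this assay, between 600 nM and 2400 nM. For compound 4 this means an expected step of a 1.1-fold higher number from compound 3 to compound 4 (0.03 log units; within the scatter).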

Compound 4, half-maximal inhibitory concentration: 2010 nM
Compound 4: the middle estimate sits 1.7-fold (0.22 log units) below what was measured, and the stated range covers the measured number.
By their numbers in this assay, from the lowest: compounds 2, 3, 1 and 4 (each within the scatter of the next, the first and the last beyond it).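

In this assay, the carbon para to a large group now carries hydrogen, bromo or methoxy, and methoxy separates from neither of the others: a 1.1-fold higher number from compound 1 to compound 4 (0.03 log units; within the scatter) for methoxy in place of hydrogen, and a 1.8-fold higher number from compound 3 to compound 4 (0.25 log units; within the scatter) for methoxy in place of bromo. The series does gain a new separation, a 2.2-fold higher number from compound 2 to compound 4 (0.34 log units; beyond the scatter), a modest step from 2-fluorophenyl to 4-methoxyphenyl, but that step changes both the substituent and the carbon it sits on, so it cannot be credited to methoxy alone, and compound 3 stays within the scatter of both compound 2 and compound 4. Nothing available explains any of these numbers.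

The compounds shown leave open whether a group of another kind on this carbon, such as an amine, a carboxylic acid or a longer alkoxy chain, would separate from compound 1 beyond the scatter. They also leave open how methoxy would read on the carbon that carries fluoro in compound 2, which is the comparison needed to tell the substituent from its place on the ring.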